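Double-Bond Configuration in a Low-Nanomolar Cytotoxic Compound

The source may hold more compounds than are shown below. What is called first, only, known or untested is meant among the compounds shown, and "the series" means these compounds.

Going by the values given here, in a functional assay on U-87MG ATCC cells (Homo sapiens) for cytotoxicity, read by MTT assay, with a stated time of 48 h (on this read-out higher numbers stand for weaker inhibition and lower numbers for stronger inhibition), compound 2 (`C/C(=N/NC(=S)Nc1ccccc1)c1ccccn1`) gives 1.4 nM as the lower of the two numbers so far. Compound 1 (`C/C(=N\NC(=S)Nc1cccc(F)c1)c1ccccn1`) gives 18 nM in the same read-out. The gap between these two numbers lies beyond the scatter. Compound 3 (`C/C(=N\NC(=S)Nc1ccccc1)c1ccccn1`) has the same atoms and bonds as compound 2 and differs only in configuration as drawn, with the two compounds have the same atoms and bonds and differ only in configuration as drawn: 1 of 1 stereo elements differ; a double bond is drawn Z in compound 2 and E in compound 3 and a double bond drawn Z in compound 2 and E in compound 3. Among the compounds with values here, no measured step covers such a change, so in this assay a small rise in the number is expected, possibly none beyond the scatter. The expected size is a 2.1-fold higher number from compound 2 to compound 3 (0.33 log units; beyond the scatter) and remains an estimate. Compound 3 is estimated at 3 nM with an expected range of 0.8 nM to 15 nM in this read-out.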

Compound 3, half-maximal inhibitory concentration: 1.4 nM
Compound 3: the middle estimate sits 2.1-fold (0.33 log units) above what was measured; the range from low to high includes it.
By their numbers in this assay, from the lowest: compounds 2 and 3 (each within the scatter of the next); then compound 1.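

In this assay, changing the double bond's configuration as drawn gives no change at the digits printed from compound 2 to compound 3 (within the scatter), so this change alone separates the two forms by nothing beyond the scatter, and the comparison is a clean one: the fact that compounds 2 and 3 differ only in the configuration as drawn

Going by these compounds alone, with the configuration as drawn held the same, hydrogen in place of fluoro on an aromatic carbon gives a 13-fold lower number from compound 1 to compound 3 (1.11 log units; beyond the scatter), a large step and the first one-place reading at this aromatic carbon.

Open, on these data alone, is whether a chloro or methoxy group or an amine there would match fluoro or hydrogen. Also open, as far as these compounds go, is whether configuration stays as silent when fluoro is present.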